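From a Cyclopentyl to a Cyclopropyl Substituent

The source may report more compounds than this note shows. Statements on the series, on what has been measured and on what is new or still open speak of the compounds shown alone.

In a functional assay on cells for positive allosteric modulation of metabotropic glutamate receptor 2 (Homo sapiens), read by fluorescence and calcium flux, with a stated time of 30 min (on this read-out lower numbers stand for an effect already at smaller amounts and higher numbers for an effect only at larger amounts of compound), compound 1 `Fc1ccc(Cn2nnc3c(Br)cccc32)c(Cl)c1` gives 190 nM, and compound 2 `Brc1ccc(Cn2nnc3c(Br)cccc32)cn1` gives 210 nM. Compound 3 `Brc1cccc2c1nnn2CC1CCCC1` gives 30 nM in this assay, the lowest of the three numbers; its gap to compound 1 and to compound 2 lies beyond the scatter, so compound 3 is the most potent of the measured set. Compound 4 `Brc1cccc2c1nnn2CC1CC1` differs from compound 3 by cyclopropyl in place of cyclopentyl on a saturated chain carbon bound to an aromatic nitrogen, a smaller ring on the saturated chain carbon bound to an aromatic nitrogen. Within the data shown here, no measured pair shows this change, so its size is not known from the data. Compound 4 is expected to give a somewhat higher number, a step estimated as a 2.7-fold higher number from compound 3 to compound 4 (0.43 log units; beyond the scatter), possibly beyond the scatter. The estimate for compound 4 in this assay is 80 nM, within 25 nM to 250 nM.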

Compound 4, half-maximal effective concentration: 70 nM
For compound 4 the middle estimate is 1.1-fold (0.06 log units) above the measured one, within the range that was stated.
By their numbers in this assay, from the lowest: compound 3; then compound 4; then compounds 1 and 2 (each within the scatter of the next).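

In this assay the change from cyclopentyl to cyclopropyl on a saturated chain carbon bound to an aromatic nitrogen gives a 2.3-fold higher number from compound 3 to compound 4 (0.37 log units; beyond the scatter) and is the only step shown at this position. The smaller ring thus costs a modest amount of potency without removing the effect. No measurement shown here offers an explanation for this step. On these data alone, it remains open how a cyclohexyl ring, an open butyl chain or an amine would read at this place, and whether the same step would hold with other groups on the shared core.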